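Notes on the step from compound 3 to compound 4

The source may report more compounds than this note shows. Statements on the series, on what has been measured and on what is new or still open speak of the compounds shown alone.

Values so far in a functional assay on HCT-116 cells (Homo sapiens) for inhibition, read by MTT assay, with a stated time of 48 h (on this read-out lower numbers stand for stronger inhibition and higher numbers for weaker inhibition), are these:
- compound 1 `COc1ccc(N(C)c2nc(C)nc3ccccc23)cc1[Se]C` gives 28 nM
- compound 2 `COc1ccc(N(C)c2nc(C)nc3ccccc23)cc1OCCCC[Se]C#N` gives 512 nM
- compound 3 `COc1ccc(N(C)c2nc(C)nc3ccccc23)cc1[Se]C#N` gives 34 nM

Compound 3 stands in the low pair of the three numbers. That pair shows a 1.2-fold higher number from compound 1 to compound 3 (0.08 log units; within the scatter) so no gap can be read from it. The remaining compound lies far off, with a 15-fold lower number from compound 2 to compound 3 (1.18 log units; beyond the scatter) in this assay as the measured distance.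

Compound 4 `COc1ccc(N(C)c2nc(C)nc3ccccc23)cc1OCCCCC[Se]C#N` differs from compound 3 on an aromatic carbon of a six-membered aromatic ring of carbon only, ortho to a methoxy group. The change a group of 9 heavy atoms (6 carbon, 1 nitrogen, 1 oxygen, 1 selenium; no ring) in place of a group of 3 heavy atoms (1 carbon, 1 nitrogen, 1 selenium; no ring), on an aromatic carbon is the whole difference.

For the measured compounds named here, the bearing evidence is the one measured compound with a long chain at this place, compound 2. It shows an 18-fold higher number from compound 1 to compound 2 (1.26 log units; beyond the scatter) and the reverse reading a 15-fold lower number from compound 2 to compound 3 (1.18 log units; beyond the scatter) and both steps are large. The swap on selenium, with a 1.2-fold higher number from compound 1 to compound 3 (0.08 log units; within the scatter) as its step, offers no guide here. A large step toward a higher number is therefore expected, though it rests on one long-chain case, and the data hold no measured comparison of chain lengths. The estimate is a 15-fold higher number from compound 3 to compound 4 (1.17 log units; beyond the scatter) as the expected change. Compound 4 is estimated at 500 nM with an expected range from 170 nM to 1500 nM as the working figure.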

Compound 4, half-maximal inhibitory concentration: 256 nM
Compound 4: middle estimate off by 2.0-fold (0.29 log units), on the high side; low and high end bracket the measured number.
By their numbers in this assay, from the lowest: compounds 1 and 3 (each within the scatter of the next); then compounds 4 and 2 (each within the scatter of the next).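

In this assay, a second long chain on this aromatic carbon, ortho to a methoxy group, shows that the result for compound 2 was not a single case, with a 7.5-fold higher number from compound 3 to compound 4 (0.88 log units; beyond the scatter) and a 9.1-fold higher number from compound 1 to compound 4 (0.96 log units; beyond the scatter) both beyond the scatter. The change on the saturated chain carbon, four bonds along the chain from an oxygen on an aromatic ring, gives a 2.0-fold lower number from compound 2 to compound 4 (0.30 log units; within the scatter) and lies within the scatter, so the two chain lengths shown cannot be told apart and no trend with length can be drawn from them. No measurement on hand accounts for the higher numbers of the two long-chain compounds.

Open, as far as these compounds go, is whether a much shorter chain on the same oxygen, or a still longer one, would bring the number back toward the low pair or carry it further up. Also open, from the compounds shown here alone, is what the chain end contributes: a chain of the same kind ending in an amine, a carboxylic acid or a plain methyl group could show whether the selenium and nitrile end has any part in these numbers.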